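This account rests on a few compounds, and the source may have more. Where it says the series, first, only, none or still open, it means among the compounds named here.

Compounds measured in a functional assay on RPMI 8402 cells (Homo sapiens) for cytotoxicity; on this read-out lower numbers stand for stronger inhibition and higher numbers for weaker inhibition:

compound 1 `CCc1nc2cc(-c3nc4cc(-c5nc6cc(-c7ccccc7)ccc6[nH]5)ccc4[nH]3)ccc2[nH]1` — 110 nM
compound 2 `CC(C)c1nc2cc(-c3nc4cc(-c5nc6cc(-c7ccccc7)ccc6[nH]5)ccc4[nH]3)ccc2[nH]1` — 60 nM
compound 3 `c1ccc(-c2ccc3[nH]c(-c4ccc5[nH]c(-c6ccc7[nH]cnc7c6)nc5c4)nc3c2)cc1` — 90 nM

Compound 3 has the second highest of the three numbers; the three values sit within the scatter of one another, so no order among them is established.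

Compound 4 `CCCc1nc2cc(-c3nc4cc(-c5nc6cc(-c7ccccc7)ccc6[nH]5)ccc4[nH]3)ccc2[nH]1` differs from compound 3 by propyl in place of hydrogen on an aromatic carbon. Among the compounds with values here, the steps that bear on this are the removal of alkyl groups at the same carbon: a 1.2-fold lower number from compound 1 to compound 3 (0.09 log units; within the scatter) and a 1.5-fold higher number from compound 2 to compound 3 (0.18 log units; within the scatter). Both are within the scatter, so an alkyl chain at this position has not shifted this assay beyond noise.

For compound 4 no step beyond the scatter is expected, a 1.1-fold lower number from compound 3 to compound 4 (0.05 log units; within the scatter); the estimate for compound 4 is 80 nM with a range of 40 nM to 180 nM.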

Compound 4, half-maximal inhibitory concentration: 60 nM
Estimate against measurement, compound 4: 1.3-fold (0.12 log units) above, and the stated range covers the measured number.
By their numbers in this assay, from the lowest: compounds 2, 4, 3 and 1 (each within the scatter of the next).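

Propyl on the aromatic carbon between two ring nitrogen atoms gives in this assay a 1.5-fold lower number from compound 3 to compound 4 (0.18 log units; within the scatter) and so, like ethyl and isopropyl, does not separate from the compound carrying hydrogen there. Among the chains themselves, propyl for isopropyl gives no change at the digits printed from compound 2 to compound 4 (within the scatter) and the one-carbon extension of ethyl gives a 1.8-fold lower number from compound 1 to compound 4 (0.26 log units; within the scatter) and neither chain length nor branching has yet moved this read-out beyond the scatter. Nothing at hand explains why these chains make so little difference.

Still open, going by these compounds, is whether a longer chain such as hexyl, or an amine or a carboxylic acid on this carbon, would give a step beyond the scatter.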